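Replacing a Dimethylfuran with a Pyridine on a Shared Core

A few compounds are considered here, and "the series" means these few. Any claim that something is new, unique, unknown or untested is made for them only; others in the source may bear on it.

Measured so far:
compound 1 `Cc1cc(-c2ccnc(Nc3ccc(N(C)C)cc3)n2)c(C)o1` gives 4900 nM in a functional assay for inhibition, with Homo sapiens as the target; a lower number here means a stronger inhibitor, a higher number a weaker inhibitor
compound 2 `Clc1cccc(Nc2nccc(-c3cccnc3)n2)c1` gives 1500 nM in this assay

Compound 1 has the higher of the two numbers; compound 2 sits a good way lower, a gap beyond the usual scatter, so compound 2 is the stronger inhibitor of the two. Compound 3 `CN(C)c1ccc(Nc2nccc(-c3ccncc3)n2)cc1` has not yet been measured. It keeps the core of compound 1 and differs only in one group: pyridin-4-yl in place of 2,5-dimethylfuran-3-yl on an aromatic carbon. Among the compounds with values here, no measured pair shows this exact change, so its effect can only be guessed. Compound 2, which also carries a pyridine on its core, gives 1500 nM, which hints that a pyridine can go with a lower number. Compound 3 is therefore expected to come in somewhat lower than compound 1, with a step of a 2.5-fold lower number from compound 1 to compound 3 (0.39 log units; beyond the scatter) in this assay, though the range is wide. The estimate for compound 3 is 2000 nM, between 500 nM and 8000 nM.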

Compound 3, half-maximal inhibitory concentration: 3700 nM
Compound 3: middle estimate off by 1.9-fold (0.27 log units), on the low side; the measured number falls inside the stated range.
By their numbers in this assay, from the lowest: compound 2; then compounds 3 and 1 (each within the scatter of the next).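

In this assay, pyridin-4-yl in place of 2,5-dimethylfuran-3-yl gives a 1.3-fold lower number from compound 1 to compound 3 (0.12 log units; within the scatter), so on this aromatic carbon of the shared core, the two rings cannot be told apart. Within the data shown here, this is the first direct reading of a change at this spot, as compound 1 and compound 2 differ in more than one place. Nothing available explains this outcome. The compounds shown do not reveal how far this spot tolerates other groups, as none carries a plain phenyl ring, a morpholine or a single methyl group there. Also open, as far as these compounds go, is whether the value of compound 2, 1500 nM, owes anything to its chlorine-bearing ring, which compound 1 and compound 3 both lack.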